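The source may hold more compounds than are shown below. What is called first, only, known or untested is meant among the compounds shown, and "the series" means these compounds.

In a functional assay on MCF7 cells (Homo sapiens) for antiproliferative activity, read by sulforhodamine B assay, with a stated time of 72 h (on this read-out higher numbers stand for weaker inhibition and lower numbers for stronger inhibition), compound 2 `COc1ncc(-c2ccc3ncnc(Nc4ccc(OCCO)c(Cl)c4)c3c2)cc1NS(=O)(=O)c1ccc(F)cc1F` gives 3740 nM, while compound 1 `COc1ncc(-c2ccc3ncnc(Nc4ccc(OCCCO)nc4)c3c2)cc1NS(=O)(=O)c1ccc(F)cc1F` gives 6120 nM; the two numbers lie within the scatter of each other. Among the compounds with values here, the only measured step, a 1.6-fold lower number from compound 1 to compound 2 (0.21 log units; within the scatter), replaced the whole ring on the aromatic nitrogen, so it speaks only loosely to a smaller change on that ring. Compound 3 `COc1cc(Nc2ncnc3ccc(-c4cnc(OC)c(NS(=O)(=O)c5ccc(F)cc5F)c4)cc23)ccc1OCCO` differs from compound 2 by methoxy in place of chloro on an aromatic carbon. Within the data shown here, no measured step isolates this swap, so no change beyond the scatter is expected. Compound 3 is expected to give about 5000 nM, within a range from 2000 nM to 12000 nM. The expected step is a 1.3-fold higher number from compound 2 to compound 3 (0.13 log units; within the scatter).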

Compound 3, half-maximal inhibitory concentration: 2260 nM
The estimate for compound 3 lay 2.2-fold (0.34 log units) above the measured number, within the range that was stated.
By their numbers in this assay, from the lowest: compounds 3, 2 and 1 (each within the scatter of the next, the first and the last beyond it).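

In this assay, methoxy in place of chloro on this aromatic carbon, ortho to the 2-hydroxyethoxy group, gives a 1.7-fold lower number from compound 2 to compound 3 (0.22 log units; within the scatter) and so shows that the two groups cannot be told apart here. Within the data shown here, the step of a 2.7-fold lower number from compound 1 to compound 3 (0.43 log units; beyond the scatter) is the first one beyond the scatter, but it replaces the whole group on the nitrogen, so no single part of that group can be credited with it. No measurement here explains either step. On these data alone, whether an amine or fluoro at this position would also leave the number within the scatter stays open.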